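A few compounds are considered here, and "the series" means these few. Any claim that something is new, unique, unknown or untested is made for them only; others in the source may bear on it.

Compounds measured so far, in a functional assay on K562 cells (Homo sapiens) for cytotoxicity, read by MTT assay, with a stated time of 72 h; a higher number here means a weaker inhibitor, a lower number a stronger inhibitor:

Compound 1, `CCCCCOCNc1n[n+]([O-])c2ccccc2[n+]1[O-]`, gives 3300 nM.
Compound 2, `COc1ccc(COCNc2n[n+]([O-])c3ccccc3[n+]2[O-])cc1`, gives 660 nM.
Compound 3, `CCCOCNc1n[n+]([O-])c2ccccc2[n+]1[O-]`, gives 3890 nM.

All three share the same core, and differ only in the chain attached through an oxygen on a saturated carbon. Compound 3 carries the highest number of the three: it sits close to compound 1, since a 1.2-fold higher number from compound 1 to compound 3 (0.07 log units; within the scatter), while compound 2 lies well apart, as a 5.9-fold higher number from compound 2 to compound 3 (0.77 log units; beyond the scatter) shows. For the measured compounds named here, the one step that moves the number beyond the scatter is the step from a chain to a ring, a 5.0-fold lower number from compound 1 to compound 2 (0.70 log units; beyond the scatter).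

Compound 4, `CCCCOCNc1n[n+]([O-])c2ccccc2[n+]1[O-]`, has not yet been measured. It differs from compound 3 by methyl in place of hydrogen on a saturated chain carbon, three bonds along the chain from an oxygen on a saturated carbon. Going by the values given here, the step that bears on this is the one between compound 1 and compound 3, where removing ethyl from the same place changed the number only within the scatter, a 1.2-fold higher number from compound 1 to compound 3 (0.07 log units; within the scatter). Adding a single carbon at that place, a smaller change than that one, is therefore expected to leave the value in this assay essentially where compound 3 stands, with at most a slight drift to a lower number; compound 4 is expected to show a 1.1-fold lower number from compound 3 to compound 4 (0.05 log units; within the scatter). The estimate for compound 4 is 3500 nM, within a range from 1800 nM to 7000 nM.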

Compound 4, half-maximal inhibitory concentration: 3240 nM
Estimate against measurement, compound 4: 1.1-fold (0.03 log units) above, within the range that was stated.
By their numbers in this assay, from the lowest: compound 2; then compounds 4, 1 and 3 (each within the scatter of the next).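

In this assay, methyl in place of hydrogen on a saturated chain carbon, three bonds along the chain from an oxygen on a saturated carbon, stays within the scatter (a 1.2-fold lower number from compound 3 to compound 4 (0.08 log units; within the scatter)). The earlier compounds shown here showed only a two-carbon change at this place, and this result adds the single-carbon steps: the further step out also stays within the scatter (a 1.0-fold lower number from compound 1 to compound 4 (0.01 log units; within the scatter)), so compounds 3, 4 and 1 form a flat run with no detectable dependence on chain length across these three members. Against this intermediate chain, 4-methoxyphenyl in compound 2 still stands apart (a 4.9-fold higher number from compound 2 to compound 4 (0.69 log units; beyond the scatter)), so among the compounds shown, replacing the chain end with this ring is the only change that goes beyond the scatter.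

Still open, going by these compounds, is whether a much longer chain, a chain ending in an amine or a carboxylic acid, or a plain phenyl without the methoxy group would give a number near the flat run or near compound 2. No measurement at hand offers a reason for the flat run or for the separate place of compound 2.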